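The source may hold more compounds than are shown below. What is called first, only, known or untested is meant among the compounds shown, and "the series" means these compounds.

Compound 1 `COCCOc1ncc(-c2nc(C(F)(F)F)sc2N2CCN(C(=O)Cn3cnc4cccnc43)[C@H](C)C2)cn1`: 324 nM
Compound 2 `CCOc1ncc(-c2nc(C(F)(F)F)sc2N2CCN(C(=O)Cn3c(=O)oc4ccccc43)[C@H](C)C2)cn1`: 99 nM

In a functional assay on U2OS cells for antagonist activity at C-X-C chemokine receptor type 3 (Homo sapiens), read by beta-arrestin recruitment (a lower number here means a stronger inhibitor, a higher number a weaker inhibitor), compound 2 gives 99 nM, the lowest of the two numbers; compound 1 gives 324 nM, a gap beyond the scatter. Compound 3 `CCOc1ncc(-c2nc(C(F)(F)F)sc2N2CCN(C(=O)Cn3cc(Cl)cn3)[C@H](C)C2)cn1` differs from compound 2 by a group of 6 heavy atoms (3 carbon, 2 nitrogen, 1 chlorine; one five-membered aromatic ring with 2 hetero atoms) in place of a group of 10 heavy atoms (7 carbon, 1 nitrogen, 2 oxygen; one five-membered aromatic ring with 2 hetero atoms, one six-membered aromatic ring of carbon only), on a saturated chain carbon bound to a carbonyl carbon. Within the data shown here, no step of this kind has been measured, so the size of the change can only be guessed; a moderate rise in the number, toward a weaker inhibitor, is expected a 2.5-fold higher number from compound 2 to compound 3 (0.40 log units; beyond the scatter). Compound 3 is therefore estimated at 250 nM, within a range of 80 nM to 800 nM.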

Compound 3, half-maximal inhibitory concentration: 272 nM
Beside the measured number, compound 3's estimate is 1.1-fold (0.04 log units) below it, and the stated range covers the measured number.
By their numbers in this assay, from the lowest: compound 2; then compounds 3 and 1 (each within the scatter of the next).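

In this assay, placing 4-chloro-1H-pyrazol-1-yl on the saturated chain carbon bound to a carbonyl carbon gives a 2.7-fold higher number from compound 2 to compound 3 (0.44 log units; beyond the scatter). This position therefore accepts a single ring of 6 heavy atoms in place of a two-ring group of 10 heavy atoms, with a modest loss of strength rather than a collapse. No measured evidence here explains the step.

From the compounds shown here alone, whether the chlorine matters remains open, and a pyrazole carrying a methyl group instead would help to test it. So does whether any ring is needed here, which a simple amine could test.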